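Isopropyl for methyl on the nitrogen of compound 3

This account rests on a few compounds, and the source may have more. Where it says the series, first, only, none or still open, it means among the compounds named here.

compound 1 `Cc1nc2cc(Cl)c(Cl)cc2[nH]1`: 51000 nM
compound 2 `COc1cc2ncn([C@@H]3O[C@H](CO)[C@@H](O)[C@H]3O)c2cc1OC`: > 100000 nM
compound 3 `Cn1c(C(F)(F)F)nc2cc(Cl)c(Cl)cc21`: 56000 nM

All three entries come from a functional assay on HCT-116 cells (Homo sapiens) for cytotoxicity, read by MTT assay, with a stated time of 48 h (on this read-out lower numbers stand for stronger inhibition of growth and higher numbers for weaker inhibition of growth), and make a thin basis for any reading of the series. The entry for compound 2 at > 100000 nM is a limit of the assay and not a number. Within the data shown here, compound 1 at 51000 nM and compound 3 at 56000 nM lie within the scatter of each other, and they are the only two true numbers in the set. Compound 3 therefore stands level with compound 1 and gives the starting point here.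

The unmeasured compound 4 `CC(C)n1c(C(F)(F)F)nc2cc(Cl)c(Cl)cc21` carries isopropyl in place of methyl on an aromatic nitrogen next to the ring atom that bears a trifluoromethyl group. Among the measured compounds shown here, no measured pair shows a change at this nitrogen, so the expectation in this assay has little to rest on beyond compound 3 at 56000 nM as its anchor. No change beyond the scatter is expected, with only a slight lean towards a lower number, and a reading reported only as a limit remains possible. The estimated step is a 1.2-fold lower number from compound 3 to compound 4 (0.09 log units; within the scatter) and stays within the scatter. Compound 4 is estimated at 45000 nM with an expected range from 18000 nM to 100000 nM in this assay.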

Compound 4, concentration for 50% growth inhibition: 81900 nM
Compound 4: the middle estimate sits 1.8-fold (0.26 log units) below what was measured; the measured number falls inside the stated range.
By their numbers in this assay, from the lowest: compounds 1, 3 and 4 (each within the scatter of the next). At a limit, above all of these: compound 2.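

In this assay, isopropyl in place of methyl on an aromatic nitrogen gives a 1.5-fold higher number from compound 3 to compound 4 (0.17 log units; within the scatter). Among these compounds, this is the first step that can be read at this nitrogen, and it shows that the exchange of methyl for isopropyl, next to the ring atom that bears a trifluoromethyl group, moves the number by no more than the usual scatter of the assay, so this position accepts the branched group without a change that can be told apart from repeat noise. Among the compounds shown here, compound 2 remains a limit and not a number, so it gives no step to set beside this one: the limit of > 100000 nM in this assay, at which 1 of the 4 values shown sits.

Going by these compounds, whether any other group on this nitrogen would move the number beyond the scatter stays open, for example a longer chain such as n-butyl, or a chain ending in an amine or a carboxylic acid. Also open, on these data alone, is what the trifluoromethyl group contributes, since compound 1 and compound 3 differ in more than one place and a direct comparison of the two is not possible.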